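A few compounds are considered here, and "the series" means these few. Any claim that something is new, unique, unknown or untested is made for them only; others in the source may bear on it.

Three compounds share one core and differ only in the aromatic group attached to it. In an assay on CHO cells for inhibition of Glucagon receptor (Homo sapiens), tested at 20 uM (a lower number here means less inhibition, a higher number more inhibition at the concentration tested (going by the name of the read-out)), compound 1 `CCCCCc1c(C(C)C)nc(C(C)C)c(CO)c1-c1ccccc1CO` gives 44%, compound 2 `CCCCCc1c(C(C)C)nc(C(C)C)c(CO)c1-c1cccc2ccccc12` gives 6%, and compound 3 `CCCCCc1c(C(C)C)nc(C(C)C)c(CO)c1-c1ccc(-c2ccccc2)cc1` gives 2%. Compound 3 holds the lowest of these three numbers; its gap to compound 2 lies within the usual scatter, while its gap to compound 1 lies beyond it. Compound 4 `CCCCCc1c(C(C)C)nc(C(C)C)c(CO)c1-c1ccc(OC)cc1` differs from compound 3 by a single change: methoxy in place of phenyl on an aromatic carbon. Among the measured compounds shown here, no measured pair differs in just one place, so the size of this step is open; a modest rise is expected, with an estimated step of a number 13 percentage points higher from compound 3 to compound 4 (beyond the scatter). In this assay compound 4 is expected to give about 15%, between 0% and 40%.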

Compound 4, a percentage reported as inhibition, at one concentration (the size of the read-out at that concentration, not a potency): 37%
Compound 4: the middle estimate sits 22 percentage points below what was measured, and the stated range covers the measured number.
By their numbers in this assay, from the lowest: compounds 3 and 2 (each within the scatter of the next); then compounds 4 and 1 (each within the scatter of the next).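

In this assay, methoxy in place of phenyl at this place, para to a large group, gives a number 35 percentage points higher from compound 3 to compound 4 (beyond the scatter), so the read-out depends strongly on what sits on this aromatic carbon. Two quite different aromatic groups can also read alike: 4-methoxyphenyl in place of 2-(hydroxymethyl)phenyl gives a number 7 percentage points lower from compound 1 to compound 4 (within the scatter). Nothing available here explains why the methoxy step is so large.

As far as these compounds go, whether an amine or a carboxylic acid at this place would read like methoxy stays open. So does whether methoxy would give the same number on another aromatic carbon.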